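A few compounds are considered here, and "the series" means these few. Any claim that something is new, unique, unknown or untested is made for them only; others in the source may bear on it.

Compound 3 `C[C@H](Nc1cc(F)c(S(=O)(=O)Nc2cscn2)cc1Cl)c1ccccc1` gives 650 nM in an assay on HEK293 cells for inhibition of SCN8A/SCN1B (Homo sapiens), read by patch clamp, with a stated time of 20 min (a higher number here means a weaker inhibitor, a lower number a stronger inhibitor), the highest of the three numbers shown. Compound 1 `CCC(Nc1ccc(S(=O)(=O)Nc2nccs2)cc1Cl)c1ccccc1` gives 50 nM in this assay, and compound 2 `C[C@H](Nc1cc(F)c(S(=O)(=O)Nc2nccs2)cc1Cl)c1ccccc1` gives 20 nM. For the measured compounds named here, the only measured step, a 33-fold higher number from compound 2 to compound 3 (1.51 log units; beyond the scatter), concerns the ring on the sulfonamide nitrogen and leaves the phenyl untouched. Compound 4 `C[C@H](Nc1cc(F)c(S(=O)(=O)Nc2cscn2)cc1Cl)c1ccccc1F` differs from compound 3 by fluoro in place of hydrogen on an aromatic carbon. Going by the values given here, no measured pair bears on this change, so the data give no ground for a step beyond the scatter in either direction. Compound 4 is therefore expected to stay close to its parent, with an estimated step of a 1.1-fold lower number from compound 3 to compound 4 (0.03 log units; within the scatter). Compound 4 is estimated at 600 nM, within a range from 200 nM to 2000 nM.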

Compound 4, half-maximal inhibitory concentration: 410 nM
The estimate for compound 4 lay 1.5-fold (0.17 log units) above the measured number; measured number inside the range.
By their numbers in this assay, from the lowest: compound 2; then compound 1; then compounds 4 and 3 (each within the scatter of the next).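

Moving from 1-phenylethyl to 1-(2-fluorophenyl)ethyl gives the first measured change on this phenyl ring in this assay (a 1.6-fold lower number from compound 3 to compound 4 (0.20 log units; within the scatter)), so compound 4 cannot be separated from compound 3 at this position. Fluoro, ortho to a large group, is thus accommodated on the 1,3-thiazol-4-yl series without a step beyond the scatter. No measurement offered here accounts for this result.

From the compounds shown here alone, it remains open whether 1-(2-fluorophenyl)ethyl behaves the same way with the 1,3-thiazol-2-yl of compound 2. Also open, going by these compounds, is how chloro, methoxy or an amine would fare at this place.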